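Chloro added to the anilino ring of compound 2

The source may report more compounds than this note shows. Statements on the series, on what has been measured and on what is new or still open speak of the compounds shown alone.

Going by the values given here, compound 2 `O=C(NC(=S)Nc1ccccc1)Nc1ccc2c(c1)C(=O)C(=O)N2Cc1ccccc1Cl` stands, in a physicochemical assay for lipophilicity, in phosphate buffer, measured as octanol-water partition (on this read-out lower numbers stand for lower lipophilicity and higher numbers for higher lipophilicity), at 3.18, the higher of the two numbers measured so far. Among the compounds with values here, the other measured member, compound 1 `O=C(NC(=S)Nc1ccccc1Cl)Nc1ccc2c(c1)C(=O)C(=O)N2Cc1ccccc1`, gives in this assay 3.01; the two values lie within the scatter of each other, and since compounds 1 and 2 differ at more than one place, no single step connects them.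

Compound 3 `O=C(NC(=S)Nc1ccccc1Cl)Nc1ccc2c(c1)C(=O)C(=O)N2Cc1ccccc1Cl` is compound 2 with one change: chloro in place of hydrogen on an aromatic carbon. Within the data shown here, no measured pair shows this change on its own, so the size of the step has to be expected rather than read from the data. The step from compound 2 to compound 3 is expected to be upward and beyond the scatter, estimated at a number 0.47 log units higher from compound 2 to compound 3 (beyond the scatter). For compound 3 the value expected in this assay is 3.65, with a range from 3.25 to 4.05.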

Compound 3, partition coefficient: 3.98
Compound 3: middle estimate off by 0.33 log units, on the low side; low and high end bracket the measured number.
By their numbers in this assay, from the lowest: compounds 1 and 2 (each within the scatter of the next); then compound 3.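

In this assay, chloro in place of hydrogen on an aromatic carbon now has a measured size: with phenyl going to 2-chlorophenyl, the read-out shows a number 0.80 log units higher from compound 2 to compound 3 (beyond the scatter), and with the same kind of change at the other chlorinated place, it shows a number 0.97 log units higher from compound 1 to compound 3 (beyond the scatter). Going by these compounds alone, compounds 1 and 2 alone, which differ at more than one place, gave no such step, whereas both new steps lie beyond the scatter and both are upward. Nothing at hand accounts for the size of either step.

Going by these compounds, both steps start from a compound already carrying one chloro, so the size of the change on a member free of chloro stays open. Also open, on these data alone, is how other groups at this place, such as methoxy, an amine or a carboxylic acid, would move the read-out.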